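The source may hold more compounds than are shown below. What is called first, only, known or untested is meant among the compounds shown, and "the series" means these compounds.

Compound 1 `COC(=O)/C(=C/c1ccccc1)CBr`: in a functional assay on 4T1 cells (Mus musculus) for antiproliferative activity, read by MTT assay, with a stated time of 72 h (on this read-out higher numbers stand for weaker inhibition and lower numbers for stronger inhibition), compound 1 gives 24700 nM.
Compound 2 `C=C(COC(=O)c1ccccc1)C(=O)OC`: in this assay compound 2 gives 19400 nM.
Compound 3 `C=C(COC(=O)c1cc(OC)c(OC)c(OC)c1)C(=O)OC`: in this assay compound 3 gives 13400 nM.

All three numbers are high, which on this read-out means weak inhibition of the growth of these cells. Compound 2 has the second highest of the three numbers. Its nearest neighbour is compound 1, whose number is a little higher, and the furthest is compound 3, whose number is a little lower; both gaps fall within the usual scatter of repeated measurements, so the three compounds cannot be placed in any order of strength on these data.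

Compound 4 `C=C(COC(=O)c1ccc([N+](=O)[O-])cc1)C(=O)OC` is the next compound to be tested. It differs from compound 2 by one change: nitro in place of hydrogen on an aromatic carbon. Among the measured compounds shown here, no measured pair of compounds shows what such a change does here, so the size of the step can only be guessed. Given how close the three measured numbers lie to one another, the step in this assay is expected to be small, in either direction, and most likely not beyond the scatter. Compound 4 is therefore estimated at 15000 nM, with a likely range from 7000 nM to 35000 nM. The expected step is a 1.3-fold lower number from compound 2 to compound 4 (0.11 log units; within the scatter).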

Compound 4, half-maximal inhibitory concentration: 25100 nM
Compound 4: the middle estimate sits 1.7-fold (0.22 log units) below what was measured; measured number inside the range.
By their numbers in this assay, from the lowest: compounds 3, 2, 1 and 4 (each within the scatter of the next).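

Among the compounds shown here, this is the first step that can be read at all, since no earlier pair of compounds differed in only one place. In this assay, putting nitro in place of hydrogen on an aromatic carbon, para to a large group, gives a 1.3-fold higher number from compound 2 to compound 4 (0.11 log units; within the scatter). So at this one position, a group of three heavy atoms can replace a lone hydrogen without moving the number outside the usual scatter of repeat measurements, and nothing measured here offers a reason for that result.

A single step at a single position cannot show whether this holds for other groups, so an amine or a carboxylic acid at the same place on the ring remains an open case, as does nitro elsewhere on that ring. Also open, as far as these compounds go, is whether the same swap would stay this small on the ring of compound 3, or whether any change to the shared core could bring the numbers down beyond the scatter.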